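The compounds below may be only part of what the source reports. "The series", "measured", "known", "first", "only" and "open" are said of these compounds alone.

Compound 1 `FC(F)(F)c1ccc(NCc2cn(-c3ccccc3)nc2-c2ccc(Br)cc2)cc1`: 46000 nM
Compound 2 `Cc1ccc(NCc2cn(-c3ccccc3)nc2-c2ccccc2)cc1`: > 100000 nM

Both compounds were tested in an ADME assay on MDBK cells (Bos taurus) for cytotoxicity, read by MTT assay, with a stated time of 72 h; on this read-out higher numbers stand for lower toxicity in this test and lower numbers for higher toxicity in this test. Compound 1 gives a true number there. Compound 2 stands at the limit of > 100000 nM in this assay, at which 1 of the 2 values shown sits, so its entry is a limit and not a number.

The next compound to be read is compound 3 `Cc1ccc(NCc2cn(-c3ccccc3)nc2-c2ccc(Br)cc2)cc1`. It differs from compound 2 by bromo in place of hydrogen on an aromatic carbon, which is bromo in place of hydrogen on an aromatic carbon, or phenyl to 4-bromophenyl. For the measured compounds named here, no measured pair of compounds shows this change alone, so the size of the step in this assay has to be judged indirectly. The expectation rests on compound 1, which also carries 4-bromophenyl and gives 46000 nM, although it differs from compound 3 elsewhere as well. A modest move towards lower numbers, meaning somewhat higher toxicity in this test, is therefore expected, and it may not clear the usual scatter. The expected step is an at least 1.5-fold lower number from compound 2 to compound 3 (0.18 log units; that floor lies within the scatter). For compound 3 the estimated value is 65000 nM, with an expected range of 32000 nM to 100000 nM.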

Compound 3, half-maximal cytotoxic concentration: > 100000 nM
Compound 3: only a limit was reported; the forecaster's own chance of this, stated with the estimate: 35%; at least 1.5-fold (0.18 log units) between middle value and limit.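

In this assay compound 3 carries only a limit, > 100000 nM, and not a number. Phenyl to 4-bromophenyl therefore leaves the methyl compound at the same limit as compound 2, so bromo on this aromatic carbon does not by itself bring the compound down to a true number, and the step between these two compounds cannot be read. The comparison that can be read lies at the other changed place, where methyl in place of trifluoromethyl on an aromatic carbon gives an at least 2.1-fold higher number from compound 1 to compound 3 (0.33 log units; beyond the scatter), so among these compounds, the only true number goes with trifluoromethyl and 4-bromophenyl together, not with 4-bromophenyl alone.

Going by these compounds, whether bromo shifts the value of the methyl compounds at all stays hidden, and any such shift cannot be sized from these entries: the limit of > 100000 nM in this assay, at which 2 of the 3 values shown sit. It also remains open how trifluoromethyl would read with plain phenyl in place of 4-bromophenyl, and how a chloro group, an amine or a carboxylic acid would read on the same aromatic carbon.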